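This account rests on a few compounds, and the source may have more. Where it says the series, first, only, none or still open, it means among the compounds named here.

Measured so far:
compound 1, `CCCCc1cnc(C(C)Cc2ccc(-c3ccccc3C(=O)O)cc2)[nH]1`, 2760 nM;
compound 2, `N#Cc1ccc(Cc2cnc(CCc3ccc(-c4ccccc4C(=O)O)cc3)[nH]2)cc1`, 5890 nM;
compound 3, `CCCCc1cnc(/C=C/c2ccc(-c3ccccc3C(=O)O)cc2)[nH]1`, 4380 nM.

All three values come from an in vitro functional assay on cells for agonist activity at Bombesin receptor subtype-3 (Homo sapiens), read by luminescence and calcium flux; on this read-out higher numbers stand for an effect only at larger amounts of compound and lower numbers for an effect already at smaller amounts. Compound 2 shows the highest number of the three. Its nearest neighbour is compound 3, whose number lies within the usual scatter of that of compound 2, so the two cannot be ordered; compound 1 sits furthest away, with a number that is lower beyond the scatter. Compound 4, `O=C(O)c1ccccc1-c1ccc(CCc2ncc(Cc3ccccc3)[nH]2)cc1`, is not yet measured. It differs from compound 2 in one place: hydrogen in place of cyano on an aromatic carbon. Going by the values given here, no measured pair in this set carries this change, so there is nothing to lean on; a step in this assay of about the scatter in either direction, or none at all, is expected. Compound 4 is expected at 5000 nM, with a range from 1800 nM to 14000 nM. That amounts to an estimated step of a 1.2-fold lower number from compound 2 to compound 4 (0.07 log units; within the scatter).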

Compound 4, half-maximal effective concentration: 205 nM
Compound 4: middle estimate off by 24-fold (1.39 log units), on the high side; the measured number lies below the stated range.
By their numbers in this assay, from the lowest: compound 4; then compounds 1, 3 and 2 (each within the scatter of the next, the first and the last beyond it).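

In this assay, hydrogen in place of cyano on this aromatic carbon gives a 29-fold lower number from compound 2 to compound 4 (1.46 log units; beyond the scatter). Going by these compounds alone, this shows that a single change at this position, going from 4-cyanobenzyl to benzyl, can move the read-out far beyond the scatter, which no earlier pair could show. Nothing measured here accounts for the size of this step.

As far as these compounds go, whether other groups at this position, such as fluorine, methoxy or an amine, would resemble hydrogen or cyano stays open. Also open, from the compounds shown here alone, is whether the same change would act alike on another linker.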